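Aryl exchange on the amidine carbon of the diaryl series

A few compounds are considered here, and "the series" means these few. Any claim that something is new, unique, unknown or untested is made for them only; others in the source may bear on it.

Measured so far in an assay on LM cells for displacement of a labelled ligand from Neuropeptide Y receptor type 5 (Homo sapiens); a higher number here means a weaker inhibitor, a lower number a stronger inhibitor:
compound 1 `Fc1ccc(C2(c3ccc(F)cc3)CNC(c3ccccc3)=N2)cc1` — 32 nM
compound 2 `N#Cc1cccc(C2=NC(c3ccc(F)cc3)(c3ccc(F)cc3)CN2)c1` — 2.7 nM
compound 3 `CN(C)c1cccc(C2=NC(c3ccc(F)cc3)(c3ccc(F)cc3)CN2)c1` — > 1000 nM

The three compounds share the core of compound 1 and differ only in the aromatic group on the carbon with a double bond to nitrogen. The step of a 12-fold lower number from compound 1 to compound 2 (1.07 log units; beyond the scatter) is large. For compound 3 the value > 1000 nM is a limit of this assay rather than a number, as noted in the limit of > 1000 nM in this assay, at which 1 of the 3 values shown sits. Compound 3 therefore stands at the weak end of the set: an at least 31-fold higher number from compound 1 to compound 3 (1.49 log units; beyond the scatter), and an at least 370-fold higher number from compound 2 to compound 3 (2.56 log units; beyond the scatter).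

Compound 4 `Fc1ccc(C2(c3ccc(F)cc3)CNC(c3cccs3)=N2)cc1` is not yet measured. The change is thiophen-2-yl in place of 3-(dimethylamino)phenyl on a carbon with a double bond to nitrogen. Among the measured compounds shown here, the steps that bear on it are an at least 31-fold higher number from compound 1 to compound 3 (1.49 log units; beyond the scatter) and an at least 370-fold higher number from compound 2 to compound 3 (2.56 log units; beyond the scatter), both large and both pointing to the 3-(dimethylamino)phenyl group as the weak partner; removing it should reverse that. Thiophen-2-yl has no measured counterpart here, so compound 1 with its plain phenyl is the nearest anchor. A large step downward is expected, an at least 25-fold lower number from compound 3 to compound 4 (1.39 log units; beyond the scatter). Compound 4 is estimated at 40 nM, in the range 10 nM to 200 nM.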

Compound 4, half-maximal inhibitory concentration: 54 nM
Compound 4: the middle estimate sits 1.4-fold (0.13 log units) below what was measured; the measured number falls inside the stated range.
By their numbers in this assay, from the lowest: compound 2; then compounds 1 and 4 (each within the scatter of the next). At a limit, above all of these: compound 3.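

In this assay, thiophen-2-yl and phenyl cannot be told apart on this carbon, with a 1.7-fold higher number from compound 1 to compound 4 (0.23 log units; within the scatter), while the unsubstituted thiophen-2-yl ring falls short of the 3-cyanophenyl group, with a 20-fold higher number from compound 2 to compound 4 (1.30 log units; beyond the scatter). Putting thiophen-2-yl in place of 3-(dimethylamino)phenyl gives an at least 18-fold lower number from compound 3 to compound 4 (1.26 log units; beyond the scatter), so the weak result goes with that substituted ring and not with every aromatic ring at this place. Compound 3 has a limit and not a number, so that step has only a minimum size: the limit of > 1000 nM in this assay, at which 1 of the 4 values shown sits.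

Going by these compounds, it remains open whether a nitrile on the thiophen-2-yl ring would repeat a 12-fold lower number from compound 1 to compound 2 (1.07 log units; beyond the scatter). Also open, on these data alone, is how a non-aromatic group such as cyclohexyl, or a phenyl ring bearing a primary amine or a carboxylic acid, would behave on this carbon.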